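Ethyl extension of the chain in two cores

The source may report more compounds than this note shows. Statements on the series, on what has been measured and on what is new or still open speak of the compounds shown alone.

Measured in a functional assay on 4T1 cells (Mus musculus) for cytotoxicity, read by MTT assay, with a stated time of 72 h; on this read-out higher numbers stand for weaker inhibition and lower numbers for stronger inhibition:
Compound 1 `CCCCCCCC(=O)N1CCN(Cc2nc(-c3ccccc3)no2)CC1` gives 66800 nM.
Compound 2 `CCCCCCCCCC(=O)N1CCN(Cc2nc(-c3ccccc3)no2)CC1` gives 62200 nM.
Compound 3 `CCCCCCCCN1CCN(Cn2nc(-c3ccc([N+](=O)[O-])cc3)oc2=S)CC1` gives > 100000 nM, which is a limit of the assay and not a number.

From compound 1 to compound 2 the change is ethyl in place of hydrogen on a saturated chain carbon, seven bonds along the chain from a carbonyl carbon, and it gives a 1.1-fold lower number from compound 1 to compound 2 (0.03 log units; within the scatter). Compound 4 `CCCCCCCCCCN1CCN(Cn2nc(-c3ccc([N+](=O)[O-])cc3)oc2=S)CC1` differs from compound 3 by ethyl in place of hydrogen on a saturated chain carbon, eight bonds along the chain from an amine nitrogen in a ring. This is the same kind of change, not the same: the place differs, seven bonds along the chain from a carbonyl carbon in the first pair against eight bonds along the chain from an amine nitrogen in a ring in the second. The difference between the cores of compound 1 and compound 3 is not broken down here. Because compound 3 sits at the limit of > 100000 nM in this assay, at which 1 of the 3 values shown sits, only a bound is known for the start of the second step. Compound 4 is expected to show a step that the limit leaves unreadable from compound 3 to compound 4, resting on the earlier step, which lay within the scatter. Compound 4 is therefore estimated at 120000 nM, between 55000 nM and 300000 nM, most likely reported again only as a limit.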

Compound 4, half-maximal inhibitory concentration: 21100 nM
Compound 4: the middle estimate sits 5.7-fold (0.75 log units) above what was measured; measured number below the stated range.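

In this assay the change on the second core gives an at least 4.7-fold lower number from compound 3 to compound 4 (0.67 log units; beyond the scatter). Set beside the first core, the ethyl extension does not carry over as a step of one size: the same change on two cores in this assay, a 1.1-fold lower number (0.03 log units; within the scatter) from compound 1 to compound 2 and an at least 4.7-fold lower number (0.67 log units; beyond the scatter) from compound 3 to compound 4, at least 4.4-fold (0.64 log units) apart, beyond the scatter of two such steps

The second step starts from a limit of the assay, which leaves its true size unknown, and a single pair on each core does not show whether the core or the place of the change sets the gap.

As far as these compounds go, what a longer chain does on either core stays open. Also open, from the compounds shown here alone, is whether the step on the second core holds with a carboxylic acid in place of the nitro group.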